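Replacing 4-fluorophenyl on the sulfonyl sulfur of compound 3

The source may hold more compounds than are shown below. What is called first, only, known or untested is meant among the compounds shown, and "the series" means these compounds.

- compound 1 `CC(O)(CS(=O)(=O)c1ccc(S(F)(F)(F)(F)F)cc1)C(=O)Nc1cccc(S(F)(F)(F)(F)F)c1` gives 17400 nM
- compound 2 `CC(O)(CS(=O)(=O)c1cccc(S(F)(F)(F)(F)F)c1)C(=O)Nc1cccc(S(F)(F)(F)(F)F)c1` gives 29400 nM
- compound 3 `CC(O)(CS(=O)(=O)c1ccc(F)cc1)C(=O)Nc1cccc(S(F)(F)(F)(F)F)c1` gives 48800 nM

All three values come from a functional assay on DU-145 cells (Homo sapiens) for antiproliferative activity, read by propidium iodide staining, with a stated time of 96 h; on this read-out lower numbers stand for stronger inhibition and higher numbers for weaker inhibition. Compound 3, at 48800 nM, lies within the scatter of compound 2, and it stands beyond the scatter from compound 1 only. Compound 4 `CC(O)(CS(=O)(=O)c1cccc(C(F)(F)F)c1)C(=O)Nc1cccc(S(F)(F)(F)(F)F)c1` differs from compound 3 by 3-(trifluoromethyl)phenyl in place of 4-fluorophenyl on a sulfonyl sulfur. For the measured compounds named here, the group on the sulfonyl sulfur also changes in the one measured step that bears on this, a 2.8-fold higher number from compound 1 to compound 3 (0.45 log units; beyond the scatter), and that step is modest. Compound 2, at 29400 nM, shows that another change of this group can leave the value within the scatter of compound 3. Going by the values given here, no measured compound yet carries the trifluoromethyl group, so only a small move toward a lower number is expected, probably within the scatter. The expected step is a 1.4-fold lower number from compound 3 to compound 4 (0.13 log units; within the scatter). For compound 4 the estimated value is 36000 nM, with an expected range from 18000 nM to 70000 nM.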

Compound 4, half-maximal inhibitory concentration: 37300 nM
Compound 4: middle estimate off by 1.0-fold (0.02 log units), on the low side; measured number inside the range.
By their numbers in this assay, from the lowest: compounds 1, 2, 4 and 3 (each within the scatter of the next, the first and the last beyond it).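

In this assay, 3-(trifluoromethyl)phenyl in place of 4-fluorophenyl on the sulfonyl sulfur gives a 1.3-fold lower number from compound 3 to compound 4 (0.12 log units; within the scatter), so this larger group adds a second exchange at this position that cannot be told apart from compound 3. Trifluoromethyl in place of the pentafluorosulfanyl group on an aromatic carbon gives a 1.3-fold higher number from compound 2 to compound 4 (0.10 log units; within the scatter), so among the compounds shown these two groups also cannot be told apart when they are compared directly on the same core. Nothing in the available data explains why these values lie so close together.

The compounds shown leave open whether an amine or a carboxylic acid on this aromatic ring would carry the value beyond the scatter of compound 3. Also open, from the compounds shown here alone, is whether trifluoromethyl in place of the pentafluorosulfanyl group of compound 1 would give as small a step.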